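Trimming a phenyl to a methyl on a weak inhibitor

The compounds below may be only part of what the source reports. "The series", "measured", "known", "first", "only" and "open" are said of these compounds alone.

Measured compounds:
Compound 1 `C#CCOc1ccc(-c2cc(-c3ccc(OCC#C)c(OCC)c3)nc(-c3ccccc3)n2)cc1`, in an assay on BTI-TN-5B1-4 cells for inhibition of Amine oxidase [flavin-containing] A (Homo sapiens), read by fluorescence and Amplex Red, using microsomes, with a stated time of 30 min; a higher number here means a weaker inhibitor, a lower number a stronger inhibitor: "not active" (no number reported)
Compound 2 `C#CCOc1ccc(-c2cc(-c3ccc(OCC#C)c(OC)c3)nc(-c3ccccc3)n2)cc1`, in this assay: 24900 nM

Compound 1 gave no inhibition that could be put into a number in this assay. For the measured compounds named here, compound 2 is therefore the only compound with a reported value, and that value, 24900 nM, marks it as a weak inhibitor. There is nothing else to rank it against, so its standing rests on this single number.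

Compound 3 `C#CCOc1ccc(-c2cc(-c3ccc(OCC#C)c(OC)c3)nc(C)n2)cc1` differs from compound 2 in one place: methyl in place of phenyl on an aromatic carbon. Going by the values given here, no pair with such a change has been measured here, so no size can be taken from the data. The starting point is already weak, and the loss of a ring leaves less of the molecule in place. The expectation is a small step toward weaker inhibition, a 1.8-fold higher number from compound 2 to compound 3 (0.26 log units; within the scatter), possibly no more than the usual scatter. Compound 3 is estimated at 45000 nM, within 12000 nM to 170000 nM.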

Compound 3, half-maximal inhibitory concentration: 25000 nM
The estimate for compound 3 lay 1.8-fold (0.26 log units) above the measured number, and the stated range covers the measured number.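

In this assay, replacing the phenyl between two ring nitrogen atoms with methyl gives a 1.0-fold higher number from compound 2 to compound 3 (0.00 log units; within the scatter), so the two numbers cannot be told apart. A six-membered aromatic ring leaves at this place and a methyl enters, and inhibition shows no measurable difference. For the compounds shown here, compound 2 alone, with only one number to its name, could not show this. No measurement shown here explains why the number holds across this change.

Going by these compounds alone, compound 2 and compound 3 are both weak inhibitors, so this result says only that neither group gives strong inhibition, not whether the place matters at all. As far as these compounds go, whether an amine, a carboxylic acid or a longer chain such as n-butyl at this carbon would shift the number remains open.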